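Changing the ring on a weakly active trifluoromethyl ketone

The source may hold more compounds than are shown below. What is called first, only, known or untested is meant among the compounds shown, and "the series" means these compounds.

In a functional assay on the whole organism for inhibition, with Hamster (Cricetinae) as the target, at a dose of 1 mg/kg by the intravenous route (on this read-out lower numbers stand for a weaker effect and higher numbers for a stronger effect at the one dose given), compound 1 `COC(=O)C(=O)[C@@H](NC(=O)[C@@H]1CCCN1C(=O)[C@@H](NC(=O)Cn1ccc(=O)n(CC(=O)O)c1=O)C(C)C)C(C)C` gives 32%. Compound 2 `CC(C)[C@H](NC(=O)Cn1ccc(=O)n(CC(=O)O)c1=O)C(=O)N1CCC[C@H]1C(=O)N[C@H](C(=O)C(F)(F)F)C(C)C` gives -1.2%, the lowest of the three values, and compound 3 `CC(C)[C@H](NC(=O)[C@@H]1CCCN1C(=O)[C@@H](NC(=O)CN1CCN(CC(=O)O)C(=O)C1=O)C(C)C)C(=O)C(=O)NCc1ccccc1` gives 31%. Among the measured compounds shown here, the one measured step, a number 33.2 percentage points lower from compound 1 to compound 2 (beyond the scatter), went with trifluoromethyl in place of methoxycarbonyl on a carbonyl carbon. Compound 4 `CC(C)[C@H](NC(=O)CN1CCN(CC(=O)O)C1=O)C(=O)N1CCC[C@H]1C(=O)N[C@H](C(=O)C(F)(F)F)C(C)C` is compound 2 with a group of 10 heavy atoms (5 carbon, 2 nitrogen, 3 oxygen; one five-membered non-aromatic ring with 2 hetero atoms) in place of a group of 12 heavy atoms (6 carbon, 2 nitrogen, 4 oxygen; one six-membered aromatic ring with 2 hetero atoms), on a saturated chain carbon bound to a carbonyl carbon. For the measured compounds named here, no measured step touches this ring: the step from compound 1 to compound 2 concerns the carbonyl carbon, and compound 3 differs from compound 1 in more than one place, so its value cannot be assigned to the ring alone. Compound 4 is therefore expected near 3%, between -10% and 18%. The expected step is a number 4.2 percentage points higher from compound 2 to compound 4 (within the scatter), none beyond the scatter.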

Compound 4, a percentage reported as inhibition, in the whole organism at one dose (the size of the read-out at that dose, not a potency): 45%
Beside the measured number, compound 4's estimate is 42 percentage points below it, outside the stated range (above it).
By their numbers in this assay, from the lowest: compound 2; then compounds 3 and 1 (each within the scatter of the next); then compound 4.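

At this position on a saturated chain carbon bound to a carbonyl carbon, the ring matters a great deal: in this assay, 3-(carboxymethyl)-2-oxoimidazolidin-1-yl brings a number 46.2 percentage points higher from compound 2 to compound 4 (beyond the scatter) when it replaces the six-membered aromatic ring. The trifluoromethyl ketone therefore does not rule out an effect in the whole animal, as compound 2 alone might suggest. No measurement here explains this gain. From the compounds shown here alone, whether a longer chain or an amine could replace the carboxymethyl arm remains open. So does whether compound 1 would gain likewise from this ring.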